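Propoxy to cyclohexyloxy: notes on compound 3

The source may report more compounds than this note shows. Statements on the series, on what has been measured and on what is new or still open speak of the compounds shown alone.

In a functional assay on MDCK cells (Canis lupus familiaris) for inhibition (on this read-out lower numbers stand for higher toxicity in this test and higher numbers for lower toxicity in this test), compound 1 `Cn1c(CC2(c3ccccc3)CO2)cc(=O)n(C)c1=O` gives 3700 nM and compound 2 `Cn1c(C[C@]2(C)CCCO2)cc(=O)n(C)c1=O` gives 1380000 nM. Compound 3 `CCCOc1nc(CC2(c3ccccc3)CO2)cc(=O)n1C` is reported as > 330000 nM, which is a limit of the assay and not a number. Going by these compounds, compound 3 therefore lies on the low-toxicity side of compound 1, while its order against compound 2 stays open.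

The next structure is compound 4 `Cn1c(OC2CCCCC2)nc(CC2(c3ccccc3)CO2)cc1=O`, with cyclohexyl in place of propyl on an oxygen on an aromatic ring. The same difference, cut one bond further out, reads propoxy to cyclohexyloxy. Going by the values given here, no measured pair shows this kind of change, so the expectation rests on the three values alone.

Compound 4 is expected to stay on the low-toxicity side, although compound 1 at 3700 nM shows that much lower numbers are possible in this series. The expected change is an at least 1.6-fold lower number from compound 3 to compound 4 (0.21 log units; that floor lies within the scatter), a modest move towards lower numbers in this assay. The assay may well report only a limit again. For compound 4 the estimated value is 200000 nM, with an expected range from 30000 nM to 700000 nM.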

Compound 4, half-maximal cytotoxic concentration: > 294000 nM
Compound 4 ended at the assay's limit; the forecaster's own chance of this, stated with the estimate: 45%; middle value at least 1.4-fold (0.16 log units) away from the limit.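

Compound 3 at > 330000 nM in this assay is a limit of the assay and not a number. Compound 4 at > 294000 nM is also a limit, and no step can be read between compound 3 and compound 4. The compounds shown leave open whether propoxy to cyclohexyloxy moves this read-out at all, and in which direction.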